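The source may report more compounds than this note shows. Statements on the series, on what has been measured and on what is new or still open speak of the compounds shown alone.

Within the data shown here, compound 2 `CC1(C)CC(=O)C2=C(C1)N(c1ccc(S(N)(=O)=O)cc1)C(N1C(=O)CCC1=O)=C(C#N)C2c1ccc(F)cc1` is the one member of the pair with a number: in a functional assay on MCF7 cells (Homo sapiens) for cytotoxicity, read by sulforhodamine B assay, with a stated time of 48 h (a higher number here means a weaker inhibitor, a lower number a stronger inhibitor), compound 2 gives 94100 nM. Compound 1 `CCNC(=S)NC1=C(C#N)C(c2ccc(F)cc2)C2=C(CC(C)(C)CC2=O)N1c1ccc(S(N)(=O)=O)cc1` gives in this assay only > 100000 nM, which is a limit of the assay and not a number. Among the measured compounds shown here, the one measured step, an at least 1.0-fold lower number from compound 1 to compound 2 (0.02 log units; that floor lies within the scatter), is therefore bounded by the limit of > 100000 nM in this assay, at which 1 of the 2 values shown sits, and shows nothing beyond the scatter. Compound 3 `CC(=O)CC(=O)NC1=C(C#N)C(c2ccc(F)cc2)C2=C(CC(C)(C)CC2=O)N1c1ccc(S(N)(=O)=O)cc1` carries ((2-oxopropyl)carbonyl)amino in place of 2,5-dioxopyrrolidin-1-yl on a double-bonded ring carbon. For the measured compounds named here, with only that step as a guide, no change beyond the scatter is expected. Compound 3 is expected near 100000 nM (range 40000 nM to 250000 nM). The expected step is a 1.1-fold higher number from compound 2 to compound 3 (0.03 log units; within the scatter).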

Compound 3, half-maximal inhibitory concentration: > 100000 nM
Compound 3: only a limit was reported (the forecaster's own chance of this, stated with the estimate: 55%); the middle value lies on the limit itself.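

In this assay compound 3 gives > 100000 nM, which is a limit of the assay and not a number. Exchanging the ring of 2,5-dioxopyrrolidin-1-yl for the open chain of ((2-oxopropyl)carbonyl)amino at this double-bonded ring carbon gives an at least 1.0-fold higher number from compound 2 to compound 3 (0.02 log units; that floor lies within the scatter), so removing the ring shows nothing beyond the scatter, and the step between compound 1 and compound 3 cannot be read. The series now gathers at one ceiling: the limit of > 100000 nM in this assay, at which 2 of the 3 values shown sit.

On these data alone, whether a free amine, a carboxylic acid or a longer chain on this carbon would give a value clear of that limit remains open.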